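The source may report more compounds than this note shows. Statements on the series, on what has been measured and on what is new or still open speak of the compounds shown alone.

Measured so far in a functional assay on PC-3 cells (Homo sapiens) for inhibition; a higher number here means a weaker inhibitor, a lower number a stronger inhibitor:
- compound 1 `Cc1c(C(=O)N/N=C\c2cc(O)ccc2O)oc2cccc(O)c12`: 95500 nM
- compound 2 `Cc1c(C(=O)N/N=C\c2ccncc2)oc2cccc(O)c12`: >= 40000 nM
- compound 3 `Cc1c(C(=O)N/N=C\c2c(O)cccc2F)oc2cccc(O)c12`: 8050 nM

The value of compound 2 is a limit of this assay, not a number (the limit of >= 40000 nM in this assay, at which 1 of the 3 values shown sits). Of the two numbers reported, compound 3 has the lower one, and the step of a 12-fold lower number from compound 1 to compound 3 (1.07 log units; beyond the scatter) is beyond the scatter. The step of an at least 4.9-fold lower number from compound 2 to compound 3 (0.69 log units; beyond the scatter) is also beyond the scatter, and the step that the limit leaves unreadable from compound 1 to compound 2 cannot be read.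

Compound 4 `COc1ccccc1/C=N\NC(=O)c1oc2cccc(O)c2c1C` is not yet measured. It differs from compound 3 in one place: 2-methoxyphenyl in place of 2-fluoro-6-hydroxyphenyl on a carbon with a double bond to nitrogen. The group that enters carries 0 hydrogen-bond donors; the group that leaves carried 1 hydrogen-bond donor.

The two readable steps both concern the group on the carbon with a double bond to nitrogen, and both were large, so this position is sensitive in this assay. With the hydroxyl donor gone, a higher number than compound 3 is expected for compound 4, with the step estimated as a 3.1-fold higher number from compound 3 to compound 4 (0.49 log units; beyond the scatter). Compound 4 is therefore estimated at 25000 nM, within 6000 nM to 100000 nM.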

Compound 4, half-maximal inhibitory concentration: 32700 nM
Compound 4: the middle estimate sits 1.3-fold (0.12 log units) below what was measured; low and high end bracket the measured number.
By their numbers in this assay, from the lowest: compound 3; then compound 4; then compound 1.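

In this assay the 2-methoxyphenyl group, which carries no hydrogen-bond donor, still gives a lower number than the 2,5-dihydroxyphenyl group (a 2.9-fold lower number from compound 1 to compound 4 (0.47 log units; beyond the scatter)), so a hydroxyl on this aryl group is not needed to go below compound 1. The loss against the 2-fluoro-6-hydroxyphenyl group is modest (a 4.1-fold higher number from compound 3 to compound 4 (0.61 log units; beyond the scatter)), but this change removes the hydroxyl and the fluorine and adds the methoxy group at once, so the step cannot be assigned to any one of them. The comparison with the pyridin-4-yl group gives only a floor (an at least 1.2-fold lower number from compound 2 to compound 4 (0.08 log units; that floor lies within the scatter)), and compound 2 carries a limit, not a number: the limit of >= 40000 nM in this assay, at which 1 of the 4 values shown sits.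

The compounds shown leave open how much of the lower number of compound 3 belongs to the hydroxyl and how much to the fluorine. A 2-hydroxyphenyl or a 2-fluorophenyl group would separate the two, and a 2-aminophenyl group would test another donor at this place.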